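From benzoyl to ((chloromethyl)carbonyl)carbamoyl on the shared core

This account rests on a few compounds, and the source may have more. Where it says the series, first, only, none or still open, it means among the compounds named here.

In a functional assay on COLO 205 cells (Homo sapiens) for antiproliferative activity, read by MTT assay (a higher number here means a weaker inhibitor, a lower number a stronger inhibitor), compound 1 `O=C(CCl)N1CCCc2cc(S(=O)(=O)N3CC(c4ccccc4)NC3=O)ccc21` gives 11200 nM and compound 2 `O=C(c1ccccc1)N1CCCc2cc(S(=O)(=O)N3CC(c4ccccc4)NC3=O)ccc21` gives 19300 nM and so stands within the scatter of compound 1. Compound 3 `O=C(CCl)NC(=O)N1CCCc2cc(S(=O)(=O)N3CC(c4ccccc4)NC3=O)ccc21` differs from compound 2 at one place, with ((chloromethyl)carbonyl)amino in place of phenyl on a carbonyl carbon is the full count of that exchange. Among the measured compounds shown here, only one measured step bears on it: a 1.7-fold higher number from compound 1 to compound 2 (0.24 log units; within the scatter) is phenyl in place of chloromethyl on a carbonyl carbon. For the measured compounds named here, that step says little here, since no measured compound carries the entering group. In this assay a modest move toward a lower number is therefore expected, with a wide margin on either side. The expected step is a 3.2-fold lower number from compound 2 to compound 3 (0.51 log units; beyond the scatter) on this estimate. For compound 3 the estimated value is 6000 nM with 1500 nM to 20000 nM as its expected range.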

Compound 3, half-maximal inhibitory concentration: 9910 nM
Estimate against measurement, compound 3: 1.7-fold (0.22 log units) below; measured number inside the range.
By their numbers in this assay, from the lowest: compounds 3, 1 and 2 (each within the scatter of the next).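

In this assay, the exchange gives a 1.9-fold lower number from compound 2 to compound 3 (0.29 log units; within the scatter) and, set against the chloromethyl group, a 1.1-fold lower number from compound 1 to compound 3 (0.05 log units; within the scatter) as well. The carbonyl carbon has now carried three different groups with no step among the listed ones leaving the scatter. This includes an entering group with no ring and with a hydrogen-bond donor, a kind of group the earlier pair did not include. No measurement offered here accounts for these numbers.

Still open, going by these compounds, is whether a group of another kind on this carbonyl carbon, such as a primary amine, a carboxylic acid or a longer alkyl chain, would produce a step beyond the scatter. On these data alone, it is also open whether the chlorine matters, which a plain acetyl in place of the chloromethylcarbonyl end could test.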